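A second chloro on the lowest compound so far

A few compounds are considered here, and "the series" means these few. Any claim that something is new, unique, unknown or untested is made for them only; others in the source may bear on it.

Values in a physicochemical assay for activation, with a stated time of 60 min (a lower number here means that less compound is needed, a higher number that more compound is needed for the effect), for the measured compounds
compound 1 `O=C1NC(=O)/C(=C\c2ccc(Cl)cc2)C2=C1CCCC2` gives 500 nM
compound 2 `O=C1NC(=O)/C(=C\c2ccc(C(=O)O)cc2)C2=C1CCCC2` gives 53000 nM
compound 3 `O=C1NC(=O)/C(=C\c2ccc(F)cc2)C2=C1CCCC2` gives 60000 nM

Compound 1 stands lowest of these three, with both others far from it. Compound 4 `O=C1NC(=O)/C(=C\c2ccc(Cl)cc2Cl)C2=C1CCCC2` keeps the chloro of compound 1 and adds chloro in place of hydrogen on an aromatic carbon, ortho to a large group and meta to a chloro group (chloro in place of hydrogen on an aromatic carbon). Two large measured steps bear on this (a 110-fold higher number from compound 1 to compound 2 (2.03 log units; beyond the scatter)) and (a 120-fold higher number from compound 1 to compound 3 (2.08 log units; beyond the scatter)). Each replaces the chloro that compound 4 retains, so neither tests the new place and neither gives a direction. No clear step is therefore expected, though the uncertainty is wide (estimated step no change at the digits printed from compound 1 to compound 4 (within the scatter)). In this assay the estimate for compound 4 is 500 nM (expected range 70 nM to 5000 nM).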

Compound 4, half-maximal effective concentration: 236000 nM
Estimate against measurement, compound 4: 470-fold (2.67 log units) below; measured number above the stated range.
By their numbers in this assay, from the lowest: compound 1; then compounds 2 and 3 (each within the scatter of the next); then compound 4.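

Adding chloro in place of hydrogen on the aromatic carbon, ortho to a large group and meta to a chloro group, gives a 470-fold higher number from compound 1 to compound 4 (2.67 log units; beyond the scatter) in this assay. The earlier steps shown here changed only the chloro already present, whereas this one shows that the number also responds strongly to this second place, with hydrogen there going with the lower value. Nothing available explains this step. Going by these compounds, whether a methoxy group or an amine at this place would follow chloro remains open, as does whether the step depends on the chloro retained from compound 1.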